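The compounds below may be only part of what the source reports. "The series", "measured", "known", "first", "only" and "open" are said of these compounds alone.

- Compound 1 `CC(C)C(Cc1ncc[nH]1)c1ccc(-c2ccc3cccc(F)c3c2)[nH]c1=O`: < 0.0667 h (a limit of the assay, not a number)
- Compound 2 `CC(C)C(c1ncco1)c1ccc(-c2ccc3cccc(F)c3c2)[nH]c1=O`: 0.08 h

Among the measured compounds shown here, in an ADME assay on microsomes from liver (Mus musculus) for metabolic stability (on this read-out lower numbers stand for a shorter-lived compound and higher numbers for a longer-lived compound), compound 2 gives 0.08 h, the only actual number so far. Compound 1 gives < 0.0667 h, which is a limit of the assay. The floor of the read-out therefore matters here: the limit of < 0.0667 h in this assay, at which 1 of the 2 values shown sits.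

Compound 3 `CC(C)C(c1ccc(-c2ccc3cccc(F)c3c2)[nH]c1=O)N1CCCCC1=O` carries 2-oxopiperidin-1-yl in place of 1,3-oxazol-2-yl on a saturated chain carbon bound to an aromatic carbon and a saturated chain carbon.

One measured step changes the same place, an at least 1.1-fold higher number from compound 1 to compound 2 (0.07 log units; that floor lies within the scatter), and it stays within the scatter. For the measured compounds named here, with only this guide, no change beyond the scatter is expected in this assay. The expected step is a 1.3-fold higher number from compound 2 to compound 3 (0.10 log units; within the scatter). Compound 3 is estimated at 0.1 h, with an expected range of 0.06 h to 0.25 h.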

Compound 3, half-life: 0.0967 h
Compound 3: middle estimate off by 1.0-fold (0.01 log units), on the high side; the measured number falls inside the stated range.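

In this assay, 2-oxopiperidin-1-yl on this saturated chain carbon brings a six-membered non-aromatic ring where 1,3-oxazol-2-yl had a five-membered aromatic ring, and the result is a 1.2-fold higher number from compound 2 to compound 3 (0.08 log units; within the scatter), so even this change of ring type gives no difference that can be told from the scatter. The other comparison is an at least 1.4-fold higher number from compound 1 to compound 3 (0.16 log units; that floor lies within the scatter), which rests on a limit of the assay rather than on a number and so shows no clear gain either. The floor of the read-out therefore stays close at this position: the limit of < 0.0667 h in this assay, at which 1 of the 3 values shown sits.

Still open, from the compounds shown here alone, is whether any group on this carbon can lift the half-life beyond the scatter. A simple amine, a carboxylic acid or an open-chain amide in this place could test that, as could a change in the shared core.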